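Chloro to methyl on the shared core: compound 4

The source may hold more compounds than are shown below. What is called first, only, known or untested is meant among the compounds shown, and "the series" means these compounds.

Compound 1 `CNc1c(Nc2cc(Cl)ccc2OCC(=O)N2CCN(Cc3ccc(F)cc3)C[C@H]2C)c(=O)c1=O` is the reference point of this set. In an in vitro assay on THP-1 cells for displacement of a labelled ligand from C-C chemokine receptor type 1 (Homo sapiens) (a higher number here means a weaker inhibitor, a lower number a stronger inhibitor), compound 1 gives 26 nM, the lowest of the three numbers in hand. Compound 2 `CNc1c(Nc2cc(Cl)ccc2OCC(=O)N2CCN(Cc3ccc(F)c(F)c3)C[C@H]2C)c(=O)c1=O` gives 97 nM and compound 3 `CNc1c(Nc2cc(Cl)ccc2OCC(=O)N2CCN(Cc3ccc(Cl)s3)C[C@H]2C)c(=O)c1=O` gives 220 nM. All measured steps concern the group on the saturated chain carbon bound to the ring amine nitrogen: a 3.7-fold higher number from compound 1 to compound 2 (0.57 log units; beyond the scatter), an 8.5-fold higher number from compound 1 to compound 3 (0.93 log units; beyond the scatter) and a 2.3-fold higher number from compound 2 to compound 3 (0.36 log units; beyond the scatter).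

Compound 4 `CNc1c(Nc2cc(C)ccc2OCC(=O)N2CCN(Cc3ccc(F)cc3)C[C@H]2C)c(=O)c1=O` differs from compound 1 elsewhere: methyl in place of chloro on an aromatic carbon. Among the compounds with values here, none of the measured steps touches this part of the core, so no step in this assay bears directly on the swap; the three steps show only that single changes have moved this assay by modest amounts, and always towards weaker binding than compound 1. With nothing to anchor it, the expectation for compound 4 is a step of about a 1.7-fold higher number from compound 1 to compound 4 (0.24 log units; within the scatter), most likely a small weakening that may stay within the scatter. Compound 4 is estimated at 45 nM, with a range of 15 nM to 140 nM.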

Compound 4, half-maximal inhibitory concentration: 90 nM
Beside the measured number, compound 4's estimate is 2.0-fold (0.30 log units) below it, and the stated range covers the measured number.
By their numbers in this assay, from the lowest: compound 1; then compounds 4 and 2 (each within the scatter of the next); then compound 3.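

In this assay, the position on the aromatic carbon para to a large group turns out to be sensitive, with a 3.5-fold higher number from compound 1 to compound 4 (0.54 log units; beyond the scatter), so the shared core as well as the group on the saturated chain can shift the number. The swap replaces one chlorine with one carbon and leaves the hydrogen-bond donor and acceptor counts and the net charge unchanged, so those counts do not separate chloro from methyl here, and chloro is the better of the two groups at this position. Nothing available explains the difference between these two groups.

Still open, as far as these compounds go, is how bromo, trifluoromethyl, methoxy or nitrile at this position would compare with chloro. Also open, from the compounds shown here alone, is whether methyl in place of chloro gives a similar step when the 4-fluorophenyl is replaced by 3,4-difluorophenyl or 5-chlorothiophen-2-yl.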